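Methoxy for Hydroxy on a Pyrazole Urea

A few compounds are considered here, and "the series" means these few. Any claim that something is new, unique, unknown or untested is made for them only; others in the source may bear on it.

Compound 2 `O=C(Nc1cccc(-n2cc(-c3ccncc3)c(-c3cc(O)cc(Cl)c3)n2)c1)Nc1ccc(Cl)c(Cl)c1` gives 10.7% in a functional assay on OVCAR-4 cells (Homo sapiens) for inhibition, read by sulforhodamine B assay, with a stated time of 48 h, tested at 10 uM; on this read-out lower numbers stand for a stronger effect and higher numbers for a weaker effect at the one concentration tested. Compound 1 `COc1cc(Cl)cc(-c2nn(-c3cccc(NC(=O)Nc4cccc(C(F)(F)F)c4)c3)cc2-c2ccncc2)c1` gives 3.28% in this assay, a number that sits within the usual scatter of the value of compound 2, so the two stand together. Compound 3 `COc1cc(Cl)cc(-c2nn(-c3cccc(NC(=O)Nc4ccc(Cl)c(Cl)c4)c3)cc2-c2ccncc2)c1` differs from compound 2 in one place: methyl in place of hydrogen on an oxygen on an aromatic ring. Compound 1 already carries the methoxy group and reads close to compound 2, so no step beyond the scatter is expected in this assay. Compound 3 is expected to give 7%, between -3% and 18%, a step of a number 3.7 percentage points lower from compound 2 to compound 3 (within the scatter).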

Compound 3, a percentage reported as activity, at one concentration (the size of the read-out at that concentration, not a potency): 13.3%
For compound 3 the middle estimate is 6.3 percentage points below the measured one, within the range that was stated.
By their numbers in this assay, from the lowest: compounds 1, 2 and 3 (each within the scatter of the next).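

In this assay, methyl in place of hydrogen on the oxygen gives a number 2.6 percentage points higher from compound 2 to compound 3 (within the scatter), so hydroxy and methoxy stand together at this position when 3,4-dichlorophenyl sits on the amide-type nitrogen. With the methoxy group kept, 3,4-dichlorophenyl in place of 3-(trifluoromethyl)phenyl on that nitrogen gives a number 10 percentage points higher from compound 1 to compound 3 (within the scatter) and so also separates nothing. No measurement at hand bears on these results. Still open, from the compounds shown here alone, is how an ethoxy group, a longer chain on the oxygen or an amine in its place would read. Also open, going by these compounds, is how compound 1 would compare with its hydroxy counterpart.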